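A few compounds are considered here, and "the series" means these few. Any claim that something is new, unique, unknown or untested is made for them only; others in the source may bear on it.

Measured in a functional assay on the whole organism (Popliteal lymph node) with Rattus norvegicus as the target; a lower number here means that less compound is needed, a higher number that more compound is needed for the effect:
- compound 1, `CCCCCCCOc1ccc(CC[C@@](N)(CO)CCC)cc1`: in this assay compound 1 gives 0.63 mg/kg.
- compound 2, `CCCCCCCOc1ccc(CC[C@](N)(CO)CCC)cc1`: in this assay compound 2 gives only a limit, > 10 mg/kg.

Compound 2 therefore stands at the limit of this assay, with no number of its own. Going by the values given here, the single measured step is an at least 15-fold higher number from compound 1 to compound 2 (1.20 log units; beyond the scatter); it rests on the limit of > 10 mg/kg in this assay, at which 1 of the 2 values shown sits, together with the fact that compounds 1 and 2 differ only in the configuration as drawn.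

Compound 3, `CCCCCCCOc1ccc(CCC(N)(CO)CO)cc1`, is next. It differs from compound 2 by 1-amino-2-hydroxy-1-(hydroxymethyl)ethyl in place of 1-amino-1-(hydroxymethyl)butyl on a saturated chain carbon, two bonds along the chain from an aromatic carbon. Compound 3 carries no stereocentre, so the configurational distinction that separates compound 1 from compound 2 is removed, and compound 3 is expected to behave closer to compound 1 than to compound 2. The step of an at least 8.3-fold lower number from compound 2 to compound 3 (0.92 log units; beyond the scatter) is accordingly expected to be a large drop in this assay. Compound 3 is estimated at 1.2 mg/kg, within a range of 0.3 mg/kg to 6 mg/kg.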

Compound 3, dose for 50% inhibition: 0.049 mg/kg
For compound 3 the middle estimate is 24-fold (1.39 log units) above the measured one; the measured number lies below the stated range.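

In this assay compounds 1 and 2 showed only that the drawn configuration at this carbon matters; compound 3 shows that the group itself also counts. 1-Amino-2-hydroxy-1-(hydroxymethyl)ethyl, which has no defined stereocentre, gives a step between two measured values when it replaces 1-amino-1-(hydroxymethyl)butyl: a 13-fold lower number from compound 1 to compound 3 (1.11 log units; beyond the scatter). The step of an at least 200-fold lower number from compound 2 to compound 3 (2.30 log units; beyond the scatter) gives only a minimum size and rests on a single value: the limit of > 10 mg/kg in this assay, at which 1 of the 3 values shown sits.

The swap changes the whole group at once, so the compounds shown do not separate the gain of the second hydroxyl from the loss of the carbon chain. As far as these compounds go, how a carboxylic acid in place of one hydroxymethyl, or a longer chain on this carbon, would read in this assay remains open.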